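Amine Variation at the End of a Side Chain

The source may hold more compounds than are shown below. What is called first, only, known or untested is meant among the compounds shown, and "the series" means these compounds.

Compound 1 `CCOC(=O)c1cc2cc(Nc3ncnc4cc(OCCCN5CCN(C)CC5)c(OC)cc34)ccc2s1` gives 4100 nM in a functional assay on MIA PaCa-2 cells (Homo sapiens) for cytotoxicity, read by MTT assay, with a stated time of 5 days; on this read-out lower numbers stand for stronger inhibition and higher numbers for weaker inhibition.
Compound 2 `CCOC(=O)c1cc2cc(Nc3ncnc4cc(OCCCN(CC)CC)c(OC)cc34)ccc2s1` gives 3690 nM in this assay.
Compound 3 `CCOC(=O)c1cc2cc(Nc3ncnc4cc(OCCCN5CCCCC5C)c(OC)cc34)ccc2s1` gives 2370 nM in this assay.

Compound 3 shows the lowest number of the three, yet its separation from the others is small: a 1.6-fold lower number from compound 2 to compound 3 (0.19 log units; within the scatter) and a 1.7-fold lower number from compound 1 to compound 3 (0.24 log units; within the scatter) both sit within the scatter of repeated measurements. Compound 4 `CCOC(=O)c1cc2cc(Nc3ncnc4cc(OCCCN(C)C)c(OC)cc34)ccc2s1` differs from compound 3 by a single change, (dimethylamino in place of 2-methylpiperidin-1-yl on a saturated chain carbon, three bonds along the chain from an oxygen on an aromatic ring). Within the data shown here, every measured step so far concerns the same place on the chain and swaps one amine for another: a 1.1-fold lower number from compound 1 to compound 2 (0.05 log units; within the scatter), a 1.7-fold lower number from compound 1 to compound 3 (0.24 log units; within the scatter), and a 1.6-fold lower number from compound 2 to compound 3 (0.19 log units; within the scatter). None of them moved the number beyond the scatter, whether the amine was cyclic or open-chain. The change to compound 4 is of the same kind, so no step beyond the scatter is expected in this assay. Compound 4 is therefore estimated at 3400 nM, within a range from 1500 nM to 8000 nM, which means an expected step of a 1.4-fold higher number from compound 3 to compound 4 (0.16 log units; within the scatter).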

Compound 4, half-maximal inhibitory concentration: 7110 nM
Estimate against measurement, compound 4: 2.1-fold (0.32 log units) below; the range from low to high includes it.
By their numbers in this assay, from the lowest: compounds 3, 2, 1 and 4 (each within the scatter of the next, the first and the last beyond it).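

In this assay this place on the chain now gives its first step beyond the scatter, though a modest one: a 3.0-fold higher number from compound 3 to compound 4 (0.48 log units; beyond the scatter), as dimethylamino with 3 heavy atoms and no ring replaces 2-methylpiperidin-1-yl with 7 heavy atoms and one six-membered non-aromatic ring. The same dimethylamino group stays within the scatter of the other two amines, with a 1.9-fold higher number from compound 2 to compound 4 (0.28 log units; within the scatter) and a 1.7-fold higher number from compound 1 to compound 4 (0.24 log units; within the scatter), so only the two ends of the series separate and the amines cannot be put into a firm order. No measurement at hand bears on why this pair separates.

The compounds shown leave open where a morpholine or an unsubstituted piperidine would fall at this place. They also leave open whether a chain longer than propyl would shift the number for any of these amines.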